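Urea series: amide head-group swap on the unsaturated linker

The compounds below may be only part of what the source reports. "The series", "measured", "known", "first", "only" and "open" are said of these compounds alone.

Compound 1 `CNC(=O)/C(C)=C/c1ccc(NC(=O)Nc2ccc(Cl)c(C(F)(F)F)c2)cc1` and compound 2 `CNC(=O)CCc1ccc(NC(=O)Nc2ccc(Cl)c(C(F)(F)F)c2)cc1` share a diaryl urea core and differ in the side chain on the aromatic ring, with 2-(methylcarbamoyl)prop-1-en-1-yl in place of 2-(methylcarbamoyl)ethyl on an aromatic carbon. In a functional assay on A-375 cells (Homo sapiens) for inhibition, read by MTT assay, with a stated time of 120 h (a higher number here means a weaker inhibitor, a lower number a stronger inhibitor), compound 1 reaches only the limit > 50000 nM. In this assay compound 2 gives 25200 nM, so an at least 1.9-fold lower number from compound 1 to compound 2 (0.29 log units; that floor lies within the scatter). Compound 3 `CC1CN(C(=O)CCc2ccc(NC(=O)Nc3ccc(Cl)c(C(F)(F)F)c3)cc2)CC(C)O1` carries the change (2,6-dimethylmorpholin-4-yl in place of methylamino on a carbonyl carbon). In this assay compound 3 reaches only the limit > 50000 nM, which makes an at least 1.9-fold higher number from compound 2 to compound 3 (0.29 log units; that floor lies within the scatter). Two of the three values sit at the limit (the limit of > 50000 nM in this assay, at which 2 of the 3 values shown sit).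

Compound 4 `C/C(=C\c1ccc(NC(=O)Nc2ccc(Cl)c(C(F)(F)F)c2)cc1)C(=O)N1CC(C)OC(C)C1` is not yet measured. It differs from compound 1 by 2,6-dimethylmorpholin-4-yl in place of methylamino on a carbonyl carbon. This is the same kind of change as in compound 3, but the carbonyl carbon sits on a double-bonded chain carbon here and on a saturated chain carbon there. The step from compound 1 is expected to read a step that the limit leaves unreadable from compound 1 to compound 4. That expectation rests on compound 2 to compound 3 giving an at least 1.9-fold higher number from compound 2 to compound 3 (0.29 log units; that floor lies within the scatter) and on compound 1 already sitting at the limit (the limit of > 50000 nM in this assay, at which 2 of the 3 values shown sit). Compound 4 is expected to give 90000 nM, within 30000 nM to 300000 nM, most likely reported as a limit.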

Compound 4, half-maximal inhibitory concentration: > 50000 nM
Compound 4 ended at the assay's limit (the forecaster's own chance of this, stated with the estimate: 85%); the middle value is on the limit's open side.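

In this assay compound 4 gives > 50000 nM, which is a limit of the assay. Compound 1 is also a limit, so no step can be read between compound 1 and compound 4: the limit of > 50000 nM in this assay, at which 3 of the 4 values shown sit.

The compounds shown leave open what 2,6-dimethylmorpholin-4-yl in place of methylamino does on a carbonyl carbon whose other neighbour is a double-bonded chain carbon.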